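Cyclopentyl for propyl on a well-tolerated compound

The source may hold more compounds than are shown below. What is called first, only, known or untested is meant among the compounds shown, and "the series" means these compounds.

Measured so far in a toxicity assay on THP-1 cells (Homo sapiens) for inhibition (a higher number here means that more compound is tolerated, a lower number that less compound is tolerated), are two limits:
- Compound 1 `Cn1c(-c2ccccc2Cl)cnc1NC(=O)c1ncc[nH]1` gives > 50000 nM as a limit
- Compound 2 `CCCn1c(-c2ccc(OC)cc2)cnc1NC(=O)c1ccc(F)cc1` gives > 100000 nM as a limit

Compound 2 thus stands at > 100000 nM in this assay as a limit and not a number. Compound 3 `COc1ccc(-c2cnc(NC(=O)c3ccc(F)cc3)n2C2CCCC2)cc1` carries cyclopentyl in place of propyl on an aromatic nitrogen and has not yet been measured. No measured step sizes this change, so no shift beyond the scatter is expected in this assay here. The expected step of a number no higher from compound 2 to compound 3 (the limit leaves the size open) is accordingly small. Compound 3 is estimated at 100000 nM with an expected range from 40000 nM to 200000 nM in this measurement.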

Compound 3, half-maximal cytotoxic concentration: > 100000 nM
Compound 3: only a limit was reported; the forecaster's own chance of this, stated with the estimate: 70%; the middle value lies on the limit itself.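

Compound 2 and compound 3 both stand only as limits in this assay, and the step between them cannot be read. The compounds shown leave open whether cyclopentyl in place of propyl changes how much compound is tolerated.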